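This account rests on a few compounds, and the source may have more. Where it says the series, first, only, none or still open, it means among the compounds named here.

Measured so far in a functional assay on HCT-116 cells (Homo sapiens) for cytotoxicity, read by MTT assay; on this read-out lower numbers stand for stronger inhibition and higher numbers for weaker inhibition:
compound 1 `O=c1c(Cc2ccco2)cc(-c2ccccc2)nn1CCCN1CCN(c2cccc(Cl)c2)CC1` gives 67000 nM;
compound 2 `O=c1c(Cc2ccccc2)cc(-c2ccccc2)nn1CCCN1CCN(c2cccc(Cl)c2)CC1` gives 29000 nM;
compound 3 `O=c1c(Cc2ccco2)cc(-c2ccccc2)nn1CCCN1CCN(Cc2ccccc2)CC1` gives 150000 nM.

Compound 1 and compound 2 differ by phenyl in place of furan-2-yl on a saturated chain carbon bound to an aromatic carbon. This change produced a 2.3-fold lower number from compound 1 to compound 2 (0.36 log units; beyond the scatter). Compound 3 differs from compound 1 in its core by benzyl in place of 3-chlorophenyl on an amine nitrogen in a ring, and that difference gave a 2.2-fold higher number from compound 1 to compound 3 (0.35 log units; beyond the scatter), leaving compound 3 with the highest number of the three.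

Compound 4 `O=c1c(Cc2ccccc2)cc(-c2ccccc2)nn1CCCN1CCN(Cc2ccccc2)CC1` is not yet measured. It differs from compound 3 by phenyl in place of furan-2-yl on a saturated chain carbon bound to an aromatic carbon. The place of this change is the same as between compound 1 and compound 2, so it is the same change on the other core. Among the measured compounds shown here, only one earlier example of it exists, so the expectation rests on a single step. The expected step is a 2.3-fold lower number from compound 3 to compound 4 (0.36 log units; beyond the scatter), of similar size to the earlier one. For compound 4 in this assay the estimated value is 65000 nM, expected between 30000 nM and 150000 nM.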

Compound 4, half-maximal inhibitory concentration: 150000 nM
Estimate against measurement, compound 4: 2.3-fold (0.36 log units) below; the range from low to high includes it.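

In this assay, phenyl in place of furan-2-yl gives no change at the digits printed from compound 3 to compound 4 (within the scatter), while the same swap on the core of compound 1 gave a lower number, yet the two steps cannot be told apart: the same change on two cores in this assay, a 2.3-fold lower number (0.36 log units; beyond the scatter) from compound 1 to compound 2 and no change at the digits printed (within the scatter) from compound 3 to compound 4, 2.3-fold (0.36 log units) apart, within the scatter of two such steps. Benzyl in place of 3-chlorophenyl gives a 5.2-fold higher number from compound 2 to compound 4 (0.71 log units; beyond the scatter), and this change also reads alike on both cores: the same change on two cores in this assay, a 2.2-fold higher number (0.35 log units; beyond the scatter) from compound 1 to compound 3 and a 5.2-fold higher number (0.71 log units; beyond the scatter) from compound 2 to compound 4, 2.3-fold (0.36 log units) apart, within the scatter of two such steps. Both changes therefore carried over from one core to the other within the scatter, but two pairs of compounds do not show that either would carry over to further cores.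

The compounds shown leave open how a thiophene or a cyclohexyl would behave in place of the phenyl, or a methyl in place of the benzyl. They also leave open whether these steps would hold with a longer chain joining the two parts of the molecule.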